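The source may hold more compounds than are shown below. What is called first, only, known or untested is meant among the compounds shown, and "the series" means these compounds.

Measured in an ADME assay on microsomes from liver (Homo sapiens) for metabolic stability, with a stated time of 30 min; a lower number here means that less of the compound is left, a higher number that more of the compound is left:
- compound 1 `COC(=O)C(=O)N[C@@H](CO)C(=O)O` gives "not determined" (no result reported)
- compound 2 `COC(=O)N[C@@H](CO)C(=O)O` gives 43%
- compound 3 `NC(=O)C(=O)N[C@@H](CO)C(=O)O` gives "not determined" (no result reported)

Compound 3 has no single number to stand on, so its place among these compounds cannot be fixed. Compound 1 is in the same position, which leaves compound 2 as the only one with a figure in this assay to work from.

Compound 4 `C=C(C)C(=O)N[C@@H](CO)C(=O)O` has not yet been measured. It carries 1-methylethenyl in place of carbamoyl on a carbonyl carbon, a change summed up as 1-methylethenyl in place of carbamoyl on a carbonyl carbon here. No pair of these compounds offers a measured step, so the data do not show what such a change does to the read-out. The expectation therefore rests on compound 2 at 43% alone. No step beyond the usual scatter is expected in either direction from that level, although so little evidence leaves the range wide. In this assay compound 4 is expected at 50% with an estimated range from 20% to 85% around it.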

Compound 4, percent of the compound remaining: 82%
The estimate for compound 4 lay 32 percentage points below the measured number; low and high end bracket the measured number.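

In this assay, 1-methylethenyl in place of methoxy on a carbonyl carbon gives a number 39 percentage points higher from compound 2 to compound 4 (beyond the scatter). This is the first measured step among these compounds, and it shows that the group on this carbonyl carbon, whose other neighbour is an amide-type nitrogen, can shift the percent remaining by more than the usual scatter. Nothing available accounts for the size of this step.

As far as these compounds go, compound 1 and compound 3 have no number, so the steps that involve them cannot be read, and how carbamoyl compares with 1-methylethenyl remains unknown. From the compounds shown here alone, it also remains open whether the number of compound 4 would hold with isopropyl, which lacks the double bond, or with a longer chain on the same carbonyl carbon.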